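Aryl in place of styryl on the saturated ring carbon

The source may hold more compounds than are shown below. What is called first, only, known or untested is meant among the compounds shown, and "the series" means these compounds.

Compound 1, `Cc1cc(O)c(C2=NN(c3ccc(S(N)(=O)=O)cc3)C(c3ccccc3O)C2)cc1Cl`, gives 2790 nM in a functional assay on A498 cells (Homo sapiens) for antiproliferative activity, with a stated time of 48 h; a higher number here means a weaker inhibitor of growth, a lower number a stronger inhibitor of growth.
Compound 2, `Cc1cc(O)c(C2=NN(c3ccc(S(N)(=O)=O)cc3)C(/C=C/c3ccccc3)C2)cc1Cl`, gives 14900 nM in this assay.

Compound 2 stands at the higher of these two numbers; the step of a 5.3-fold higher number from compound 1 to compound 2 (0.73 log units; beyond the scatter) lies beyond the scatter, so compound 2 is the weaker inhibitor of growth. Compound 3, `COc1ccc(C2CC(c3cc(Cl)c(C)cc3O)=NN2c2ccc(S(N)(=O)=O)cc2)cc1OC`, has not yet been measured. It differs from compound 2 in one place: 3,4-dimethoxyphenyl in place of 2-phenylethenyl on a saturated ring carbon. Among the measured compounds shown here, only one measured step bears on this change, and it runs the opposite way, from an aromatic ring on that carbon to a 2-phenylethenyl. Because a 5.3-fold higher number from compound 1 to compound 2 (0.73 log units; beyond the scatter) raised the number by a modest amount, putting an aromatic ring back is expected to lower it by a similar amount. Compound 3 is therefore estimated at 4000 nM, with a range of 1500 nM to 12000 nM, an expected step of a 3.7-fold lower number from compound 2 to compound 3 (0.57 log units; beyond the scatter).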

Compound 3, concentration for 50% growth inhibition: 3980 nM
Estimate against measurement, compound 3: 1.0-fold (0.00 log units) above, and the stated range covers the measured number.
By their numbers in this assay, from the lowest: compounds 1 and 3 (each within the scatter of the next); then compound 2.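

In this assay, putting 3,4-dimethoxyphenyl in place of 2-phenylethenyl on the saturated ring carbon gives a 3.7-fold lower number from compound 2 to compound 3 (0.57 log units; beyond the scatter), so a second, differently substituted aromatic ring also gives a stronger inhibitor of growth than 2-phenylethenyl. Exchanging the two aromatic groups gives a 1.4-fold higher number from compound 1 to compound 3 (0.15 log units; within the scatter), so this assay does not separate 2-hydroxyphenyl from 3,4-dimethoxyphenyl. No measurement here explains these steps.

Still open, on these data alone, is whether this carbon needs an aromatic ring at all, or whether a plain butyl chain would serve as well. As far as these compounds go, how a phenyl ring carrying an amine or a carboxylic acid would behave also remains unknown.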